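A Larger Side Chain Built onto Compound 2

The source may report more compounds than this note shows. Statements on the series, on what has been measured and on what is new or still open speak of the compounds shown alone.

Measured so far:
compound 1 `CC(=O)Nc1ccc(O)c(C(=O)O)c1`: 1.3%
compound 2 `Cc1ncc([N+](=O)[O-])n1CCOC(=O)c1cc(NC(=O)[C@H](C)NC(=O)OCc2ccccc2)ccc1O`: 37.1%

In a functional assay on the whole organism (strain Wistar) for inhibition, with Rattus norvegicus as the target, read by paw edema, with stated times of 1 h and 3 h, at a dose of 10 mg/kg by the intraperitoneal route (a higher number here means more inhibition at the dose given (going by the name of the read-out), a lower number less inhibition), compound 2 gives 37.1%, the highest of the two numbers; its nearest neighbour is compound 1, whose number lies lower by a gap beyond the scatter. Compound 3 `Cc1ncc([N+](=O)[O-])n1CCOC(=O)c1cc(NC(=O)[C@@H](NC(=O)OCc2ccccc2)C(C)C)ccc1O` has not yet been measured. It differs from compound 2 in one place: isopropyl in place of methyl on a saturated chain carbon bound to an amide-type nitrogen and a carbonyl carbon. Going by the values given here, no measured pair shows a step of this kind, so no change beyond the scatter is expected in either direction. Compound 3 is expected to give about 35%, within 15% to 55%. The expected step is a number 2.1 percentage points lower from compound 2 to compound 3 (within the scatter).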

Compound 3, a percentage reported as inhibition, in the whole organism at one dose (the size of the read-out at that dose, not a potency): 61.5%
Beside the measured number, compound 3's estimate is 26.5 percentage points below it, outside the stated range (above it).
By their numbers in this assay, from the lowest: compound 1; then compound 2; then compound 3.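

In this assay, putting isopropyl in place of methyl on the saturated chain carbon bound to an amide-type nitrogen and a carbonyl carbon gives a number 24.4 percentage points higher from compound 2 to compound 3 (beyond the scatter). Going by these compounds alone, this is the first step read at this position, and it shows that the group on this carbon can clearly move the inhibition seen at this dose. Nothing available explains the step.

On these data alone, whether a longer chain such as isobutyl, a benzyl group or an amine on this carbon would raise the number further or lower it remains open. A single step also cannot show a trend across such groups.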